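The compounds below may be only part of what the source reports. "The series", "measured", "known", "first", "only" and "open" are said of these compounds alone.

Measured so far in a functional assay on DU-145 cells (Homo sapiens) for inhibition, read by trypan blue exclusion, with a stated time of 72 h; a higher number here means a weaker inhibitor, a lower number a stronger inhibitor:
compound 2 `Cn1c(=O)c(S(=O)(=O)Cc2ccc(F)cc2F)cc2cnc(Nc3ccc4[nH]ccc4c3)nc21`: 1000 nM
compound 1 `Cn1c(=O)c(S(=O)(=O)c2ccc(F)cc2)cc2cnc(Nc3ccc4occc4c3)nc21`: 5000 nM

Compound 2 gives the lower of the two numbers in this assay; compound 1 sits higher by a gap beyond the usual scatter. Compound 3 `Cn1c(=O)c(S(=O)(=O)Nc2ccc(F)cc2F)cc2cnc(Nc3ccc4[nH]ccc4c3)nc21` differs from compound 2 in one place: (2,4-difluorophenyl)amino in place of 2,4-difluorobenzyl on a sulfonyl sulfur. Among the measured compounds shown here, no measured pair carries this change, so nothing anchors its effect. A small step is expected from compound 2 to compound 3 in this assay, a 1.5-fold higher number from compound 2 to compound 3 (0.18 log units; within the scatter), toward a slightly higher number but not clearly beyond the scatter. Compound 3 is therefore estimated at 1500 nM in this assay, within 400 nM to 6000 nM.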

Compound 3, half-maximal inhibitory concentration: 5000 nM
Estimate against measurement, compound 3: 3.3-fold (0.52 log units) below; low and high end bracket the measured number.
By their numbers in this assay, from the lowest: compound 2; then compounds 1 and 3 (each within the scatter of the next).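

On a sulfonyl sulfur, (2,4-difluorophenyl)amino in place of 2,4-difluorobenzyl gives a 5.0-fold higher number from compound 2 to compound 3 (0.70 log units; beyond the scatter) in this assay. This position therefore responds to a single swap between groups with the same count of heavy atoms and the same aromatic ring, differing in one nitrogen for one carbon and in one hydrogen-bond donor. Nothing available accounts for the size of this step. Going by these compounds, what a morpholine, a simple alkyl amine or a longer alkyl chain on the sulfonyl sulfur would give remains open. On these data alone, whether this step carries over to other aromatic amines on the shared core also remains open.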